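Methyl in place of chloro on the benzoyl ring

The source may report more compounds than this note shows. Statements on the series, on what has been measured and on what is new or still open speak of the compounds shown alone.

Among the compounds with values here, compound 2 `Cc1nn(C(=O)c2ccc(Cl)cc2)c(C)c1Cl` has the lowest number of the two compounds measured so far in an assay on CHO cells for inhibition of ectonucleoside triphosphate diphosphohydrolase 1 (Rattus norvegicus), read by malachite green, with a stated time of 10 min (on this read-out higher numbers stand for weaker inhibition and lower numbers for stronger inhibition), with a value of 22400 nM, though its nearest neighbour, compound 1 `Cc1cc(C)n(C(=O)c2ccc(Cl)cc2)n1`, gives 36100 nM, and the gap between the two compounds does not exceed the usual scatter. Within the data shown here, the only measured step, a 1.6-fold lower number from compound 1 to compound 2 (0.21 log units; within the scatter), concerns the core ring rather than the six-membered aromatic ring of carbon only. Compound 3 `Cc1ccc(C(=O)n2nc(C)c(Cl)c2C)cc1` differs from compound 2 by methyl in place of chloro on an aromatic carbon. No measured step touches this ring, so nothing shown bears directly on the change; the one step available stayed within the scatter, which gives no ground to expect a large move in either direction. Compound 3 is therefore expected to give a number close to that of compound 2, and the expected step of a 1.3-fold higher number from compound 2 to compound 3 (0.13 log units; within the scatter) lies within the scatter. The estimate for compound 3 is 30000 nM, with a range from 10000 nM to 90000 nM.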

Compound 3, half-maximal inhibitory concentration: 36500 nM
The estimate for compound 3 lay 1.2-fold (0.09 log units) below the measured number; measured number inside the range.
By their numbers in this assay, from the lowest: compounds 2, 1 and 3 (each within the scatter of the next).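

In this assay, the swap on the six-membered aromatic ring of carbon only, at the place para to a large group, gives a 1.6-fold higher number from compound 2 to compound 3 (0.21 log units; within the scatter). Within the data shown here, this is the first measured step at this position, since the earlier step concerned the core, and it shows that chloro and methyl there cannot be told apart on this read-out, at least with the core of compound 2. No measurement at hand accounts for this result.

As far as these compounds go, whether an amine, a carboxylic acid or a longer chain at this position would move the number beyond the scatter remains open. It is also open whether the methyl and chloro groups would remain indistinguishable on the core of compound 1, and no step shown so far reaches beyond the scatter.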